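The source may hold more compounds than are shown below. What is called first, only, known or untested is meant among the compounds shown, and "the series" means these compounds.

Compound 2, with the structure `Oc1ccccc1N1CCN(CC(O)COc2ccc(O)c3ccccc23)CC1`, is one of two closely related compounds examined in an ADME assay on HEK293 cells (Homo sapiens) for cytotoxicity, read by MTT assay, with a stated time of 48 h; a lower number here means a stronger inhibitor, a higher number a weaker inhibitor. In this assay compound 2 returns only a limit of the assay, > 50000 nM, and not a number. Its companion, compound 1, with the structure `Oc1ccc(N2CCN(CC(O)COc3cccc4ccccc34)CC2)c(O)c1`, is likewise assigned a limit in this assay, > 50000 nM. What is known of this small set is thus summarized by the limit of > 50000 nM in this assay, at which 2 of the 2 values shown sit, so compound 2 stands where compound 1 stands, at the edge of what this assay reports.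

The step under consideration leads to compound 3, with the structure `Oc1ccccc1N1CCN(CC(O)COc2cccc3ccccc23)CC1`, which has not yet been measured in this assay. The change from compound 2 is hydrogen in place of hydroxy on an aromatic carbon.

Among the measured compounds shown here, no measured step between the two known compounds exists, so the expected size of the step is taken from the fact that both of them sit at the limit. Compound 3 is therefore expected to remain at or beyond the same limit, with the step that the limit leaves unreadable from compound 2 to compound 3 expected to be none beyond the scatter. The estimate for compound 3 is 60000 nM, with a range from 30000 nM to 150000 nM.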

Compound 3, half-maximal inhibitory concentration: > 50000 nM
Compound 3 ended at the assay's limit; the forecaster's own chance of this, stated with the estimate: 85%; the middle value is on the limit's open side.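

In this assay compound 3 gives > 50000 nM, a limit and not a number. Among the compounds shown here, no step from compound 1 or compound 2 to compound 3 can therefore be read, since all three stand together: the limit of > 50000 nM in this assay, at which 3 of the 3 values shown sit.

The compounds shown leave open whether any change to the shared core would give a number in this assay at all.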